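Lengthening the linker on an iodoacetamide nucleotide analogue

This account rests on a few compounds, and the source may have more. Where it says the series, first, only, none or still open, it means among the compounds named here.

Measured so far:
Compound 1 `CN(CCCCN(C)C(=O)CCCCNc1ncnc2c1ncn2[C@@H]1O[C@H](COP(=O)(O)OP(=O)(O)OP(=O)(O)O)[C@@H](O)[C@H]1O)C(=O)CCCCNC(=O)CI` gives 0% in an assay on isolated protein for inhibition of hexokinase-3 (Rattus norvegicus), with a stated time of 6 h, tested at 10 mM; a lower number here means less inhibition, a higher number more inhibition at the concentration tested (going by the name of the read-out).
Compound 2 `Nc1ncnc2c1nc(NCCCCCCNC(=O)CI)n2[C@@H]1O[C@H](COP(=O)(O)OP(=O)(O)OP(=O)(O)O)[C@@H](O)[C@H]1O` gives 0% in this assay.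
Compound 3 `O=C(CI)NCCCCCCCCNc1ncnc2c1ncn2[C@@H]1O[C@H](COP(=O)(O)OP(=O)(O)OP(=O)(O)O)[C@@H](O)[C@H]1O` gives 47% in this assay.

Compound 2 stands level with compound 1 at the digits shown, the two together forming the lowest pair among the three numbers; the gap to compound 1 lies within the scatter, so nothing can be said about order between them. Compound 3 stands furthest away, its reading being higher by a gap that is beyond the scatter.

Compound 4 `Nc1ncnc2c1nc(NCCCCCCCCNC(=O)CI)n2[C@@H]1O[C@H](COP(=O)(O)OP(=O)(O)OP(=O)(O)O)[C@@H](O)[C@H]1O` has not yet been measured. It differs from compound 2 in one place: 2-(((iodomethyl)carbonyl)amino)ethyl in place of ((iodomethyl)carbonyl)amino on a saturated chain carbon, six bonds along the chain from a nitrogen on an aromatic ring. In plain terms, the chain that carries the iodoacetamide group is extended, while the shared core and the point of attachment on the aromatic ring nitrogen stay the same.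

Among the measured compounds shown here, no measured pair shows this exact change, so its size is unknown. Compound 3 carries a longer chain than compound 2, but at a different point of the core, so it offers only a hint. A small rise, possibly none beyond the scatter, is expected: the step from compound 2 to compound 4 is estimated at a number 12 percentage points higher from compound 2 to compound 4 (beyond the scatter). Compound 4 is therefore expected to give about 12%, within a range of 0% to 40%.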

Compound 4, a percentage reported as inhibition, at one concentration (the size of the read-out at that concentration, not a potency): 0%
Compound 4: middle estimate off by 12 percentage points, on the high side; low and high end bracket the measured number.
By their numbers in this assay, from the lowest: compounds 1, 2 and 4 (each within the scatter of the next); then compound 3.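

In this assay the reading shows no change at the digits printed from compound 2 to compound 4 (within the scatter) when 2-(((iodomethyl)carbonyl)amino)ethyl replaces ((iodomethyl)carbonyl)amino on a saturated chain carbon, six bonds along the chain from a nitrogen on an aromatic ring. Among the compounds shown here, this pair gives the first direct test of chain length at this position, as none of the earlier compounds differed from one another in only one place, and here the longer chain brings no measurable inhibition at the concentration tested. Nothing available accounts for this outcome.

Going by these compounds, since compound 2 and compound 4 both read at the bottom of the scale, it remains open whether a still longer chain, or a chloroacetamide in place of the iodoacetamide, would give any inhibition with the chain attached at this point. Compound 3 differs from compound 4 in more than one place, so this pair cannot show whether the point of attachment on the shared core decides the reading.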